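Extending the cyclohexenyl arm on the pyridine of compound 2

The source may report more compounds than this note shows. Statements on the series, on what has been measured and on what is new or still open speak of the compounds shown alone.

Measured so far:
compound 1 `CC(C(=O)NCc1ccc(C(F)(F)F)nc1C1CC2CCC1C2)c1ccc(NS(C)(=O)=O)c(F)c1` gives 1.5 nM
compound 2 `CC(C(=O)NCc1ccc(C(F)(F)F)nc1C1=CCCCC1)c1ccc(NS(C)(=O)=O)c(F)c1` gives 0.7 nM

Both compounds share a core and differ only in the group on the aromatic carbon next to the ring nitrogen. In an assay on CHO cells for antagonist activity at transient receptor potential cation channel subfamily V member 1 (Homo sapiens), read by FLIPR and calcium flux (on this read-out lower numbers stand for stronger inhibition and higher numbers for weaker inhibition), compound 2 holds the lowest of the two numbers shown; its nearest neighbour is compound 1, and the step of a 2.1-fold lower number from compound 1 to compound 2 (0.33 log units; beyond the scatter) lies beyond the scatter, though it is modest.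

Compound 3 `CC(C(=O)NCc1ccc(C(F)(F)F)nc1/C=C/C1CCCCC1)c1ccc(NS(C)(=O)=O)c(F)c1` has not yet been measured. Its structural change relative to compound 2 is 2-cyclohexylethenyl in place of cyclohex-1-en-1-yl on an aromatic carbon. Going by the values given here, the only measured step, from compound 1 to compound 2, replaced one ring system with another at the same place; it does not speak to an extension of the ring by an ethenyl link. Among the compounds with values here, there is therefore no measured step that bears directly on this change, and no step beyond the scatter is expected in this assay in either direction, with a slight lean toward a higher number.

Compound 3 is estimated at 1.2 nM, with a range from 0.4 nM to 4 nM, which is expected to mean a step of a 1.7-fold higher number from compound 2 to compound 3 (0.23 log units; within the scatter).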

Compound 3, inhibition constant: 0.7 nM
The estimate for compound 3 lay 1.7-fold (0.23 log units) above the measured number; the measured number falls inside the stated range.
By their numbers in this assay, from the lowest: compounds 2 and 3 (each within the scatter of the next); then compound 1.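

At this place, on an aromatic carbon next to the ring nitrogen, this assay shows no change at the digits printed from compound 2 to compound 3 (within the scatter) when 2-cyclohexylethenyl stands in place of cyclohex-1-en-1-yl. The six-membered carbon ring can therefore sit at the end of an ethenyl link with no loss of inhibition in this assay. Going by these compounds alone, earlier, the only comparison was between two groups with their rings attached directly to the aromatic carbon; the extended group now gives a 2.1-fold lower number from compound 1 to compound 3 (0.33 log units; beyond the scatter) and, like cyclohex-1-en-1-yl, stands apart from the group in compound 1. No evidence is available on what lies behind this result.

The compounds shown leave open how much further this place accepts extension, for example with a longer chain ending in the same cyclohexyl ring, and whether the ethenyl double bond is needed, which a saturated 2-cyclohexylethyl group would test. They also leave open how an aromatic phenyl ring or an amine such as piperidine would read at this place in this assay and whether the tolerance seen here reaches beyond carbon-only groups.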